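The source may hold more compounds than are shown below. What is called first, only, known or untested is meant among the compounds shown, and "the series" means these compounds.

Measured so far in a functional assay on MCF7 cells (Homo sapiens) for cytotoxicity, read by MTT assay, with a stated time of 48 h; on this read-out lower numbers stand for stronger inhibition and higher numbers for weaker inhibition:
compound 1 `CNC(=O)CSc1nc2ccc(NC(=O)c3ccccc3OC)cc2s1` gives 23400 nM;
compound 2 `CNC(=O)CSc1nc2ccc(NC(=O)c3ccc([N+](=O)[O-])cc3)cc2s1` gives only a limit, > 100000 nM.

Going by the values given here, compound 1 holds the only real number among the two values shown; the other is a limit. The step of an at least 4.2-fold higher number from compound 1 to compound 2 (0.63 log units; beyond the scatter) lies beyond the scatter, its size bounded by the limit of > 100000 nM in this assay, at which 1 of the 2 values shown sits. Compound 3 `COc1ccccc1C(=O)Nc1ccc2nc(SCC(=O)NCc3ccc(Cl)cc3)sc2c1` differs from compound 1 by 4-chlorophenyl in place of hydrogen on a saturated chain carbon bound to an amide-type nitrogen, leaving the 2-methoxyphenyl amide untouched. Among the compounds with values here, no measured step touches that end of the molecule: the single step recorded, from compound 1 to compound 2, swaps the aryl on a carbonyl carbon and so says nothing about methyl to 4-chlorobenzyl. With no guide in either direction, compound 3 is expected to stay near compound 1, within the scatter, a 1.3-fold lower number from compound 1 to compound 3 (0.11 log units; within the scatter). In this assay compound 3 is estimated at 18000 nM, with a range from 4000 nM to 80000 nM.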

Compound 3, half-maximal inhibitory concentration: 1100 nM
Compound 3: middle estimate off by 16-fold (1.21 log units), on the high side; the measured number lies below the stated range.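

The end of the molecule bearing the methylcarbamoyl group, which the earlier step left alone, proves highly responsive in this assay: with the 2-methoxyphenyl amide held fixed, replacing methyl with 4-chlorobenzyl gives a 21-fold lower number from compound 1 to compound 3 (1.33 log units; beyond the scatter). Going by these compounds alone, this is the first evidence that the group on the amide-type nitrogen affects this read-out, and the step is large, whereas the earlier comparison spoke only to the aryl on a carbonyl carbon. Nothing among the data shown explains why this change lowers the number.

Still open, on these data alone, is whether the chlorine is needed, which an unsubstituted benzyl would test, or whether a longer chain such as 2-phenylethyl on the same nitrogen would serve as well. Also open, as far as these compounds go, is whether 4-chlorobenzyl would have any such effect on the 4-nitrophenyl amide of compound 2, whose > 100000 nM is a limit.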